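The source may hold more compounds than are shown below. What is called first, only, known or untested is meant among the compounds shown, and "the series" means these compounds.

Compound 1 `CC1OC(OC2CCCCC2OCCCCCCCC(C(=O)O)C(=O)O)C(O)C(O)C1O` and compound 2 `CC1OC(OC2CCCCC2OCCCCCCCCC(C(=O)O)C(=O)O)C(O)C(O)C1O` share one core. In a functional assay on HL-60 cells (Homo sapiens) for inhibition (on this read-out lower numbers stand for stronger inhibition and higher numbers for weaker inhibition), compound 1 reaches only a limit of the assay, > 5000000 nM. Compound 2 likewise gives only a limit, > 5000000 nM. The change between them, (2,2-dicarboxyethyl in place of dicarboxymethyl on a saturated chain carbon, seven bonds along the chain from an oxygen on a saturated carbon), thus yields a step whose size cannot be read: a step that the two limits leave unreadable from compound 1 to compound 2. Compound 3 `CC1OC(OC2CCCCC2OC(=O)NCCCC(C(=O)O)C(=O)O)C(O)C(O)C1O` rests on a different core; how its core differs from that of compound 1 is not broken down here. In this assay, within the data shown here, compound 3 gives 700000 nM, the only number among the three values. The other two sit at the limit of > 5000000 nM in this assay, at which 2 of the 3 values shown sit. Compound 4 `CC1OC(OC2CCCCC2OC(=O)NCCCCC(C(=O)O)C(=O)O)C(O)C(O)C1O` has not yet been measured. It differs from compound 3 by 2,2-dicarboxyethyl in place of dicarboxymethyl on a saturated chain carbon, three bonds along the chain from an amide-type nitrogen, the same kind of change as that from compound 1 to compound 2, though the place differs: there it sat seven bonds along the chain from an oxygen on a saturated carbon, here three bonds along the chain from an amide-type nitrogen. Because the measured step that the two limits leave unreadable from compound 1 to compound 2 is unreadable, it gives no guide to size. Compound 4 is expected to move by an estimated no change at the digits printed from compound 3 to compound 4 (within the scatter). Resting on the value of compound 3, 700000 nM, compound 4 is estimated at 700000 nM, between 200000 nM and 3000000 nM.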

Compound 4, half-maximal inhibitory concentration: 4500000 nM
Compound 4: the middle estimate sits 6.4-fold (0.81 log units) below what was measured, and the stated range ends below it.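

In this assay the change from dicarboxymethyl to 2,2-dicarboxyethyl, on a saturated chain carbon, three bonds along the chain from an amide-type nitrogen, gives a 6.4-fold higher number from compound 3 to compound 4 (0.81 log units; beyond the scatter), so on this core the step lies beyond the scatter and goes towards weaker inhibition. On the core of compound 1 the same change cannot be read, because compound 1 and compound 2 each give only a limit of the assay and not a number: the limit of > 5000000 nM in this assay, at which 2 of the 4 values shown sit. The series therefore gives one readable step, on the core of compound 3 alone, and does not show whether its size or even its direction carries over to the core of compound 1.

The compounds shown leave open whether inhibition keeps weakening on the core of compound 3 as the group grows to 3,3-dicarboxypropyl or 4,4-dicarboxybutyl. They also leave open how a phosphonic acid in place of the two carboxylic acids would read on either core.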